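The source may report more compounds than this note shows. Statements on the series, on what has been measured and on what is new or still open speak of the compounds shown alone.

The measured compounds:

Compound 1, `COc1cc2ncnc(Nc3cccc(Cl)c3)c2cc1OCCCCC(=O)Nc1ccc(S(N)(=O)=O)cc1`, gives 33200 nM in a functional assay on NCI-H1975 cells (Homo sapiens) for antiproliferative activity, read by MTT assay, with a stated time of 72 h; a lower number here means a stronger inhibitor, a higher number a weaker inhibitor.
Compound 2, `COc1cc2ncnc(Nc3cccc(C)c3)c2cc1OCCCCC(=O)Nc1ccc(S(N)(=O)=O)cc1`, gives 32100 nM.
Compound 3, `NS(=O)(=O)c1ccc(NC(=S)Nc2ccc3ncnc(Nc4cccc(Cl)c4)c3c2)cc1`, gives 39800 nM.

Compounds 1 and 2 differ in one place only: methyl in place of chloro on an aromatic carbon. That change made the step of a 1.0-fold lower number from compound 1 to compound 2 (0.01 log units; within the scatter), so the two numbers cannot be told apart by this measurement. Compound 3 has a different core from compound 1; the difference between the two cores is not broken down here, and the values of compound 1 and compound 3 stand within the usual scatter of each other, as do those of compound 2 and compound 3.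

Compound 4, `Cc1cccc(Nc2ncnc3ccc(NC(=S)Nc4ccc(S(N)(=O)=O)cc4)cc23)c1`, has not yet been measured. It differs from compound 3 by the same change that leads from compound 1 to compound 2: methyl in place of chloro on an aromatic carbon. The place description is the same word for word in both pairs, so this is the same change on a different core.

The expected step of a 1.0-fold lower number from compound 3 to compound 4 (0.01 log units; within the scatter) is small, because the same change between compound 1 and compound 2 gave a 1.0-fold lower number from compound 1 to compound 2 (0.01 log units; within the scatter). Compound 4 is therefore expected to give about 39000 nM in this assay, with a range from 20000 nM to 80000 nM. This estimate rests on three compounds only and on one measured instance of the change, so a shift beyond the scatter cannot be ruled out.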

Compound 4, half-maximal inhibitory concentration: 35400 nM
For compound 4 the middle estimate is 1.1-fold (0.04 log units) above the measured one; low and high end bracket the measured number.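

On the core of compound 3, methyl in place of chloro gave a 1.1-fold lower number from compound 3 to compound 4 (0.05 log units; within the scatter) in this assay, so this measurement cannot tell the two compounds apart. As far as the measurement can tell, the change behaves alike on the two cores: the same change on two cores in this assay, a 1.0-fold lower number (0.01 log units; within the scatter) from compound 1 to compound 2 and a 1.1-fold lower number (0.05 log units; within the scatter) from compound 3 to compound 4, 1.1-fold (0.04 log units) apart, within the scatter of two such steps

This agreement is real but limited: in both pairs the swap leaves the number within the scatter, so the result shows only that no shift can be seen on either core. It does not test whether a change with a clear effect on one core would carry over to the other, and it says nothing about any third core in the series.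

The compounds shown carry only chloro or methyl at this place on the ring, so it remains open whether a group such as an amine or a nitrile there would move the number beyond the scatter on either core. Also open, on these data alone, is whether a carboxylic acid in place of the sulfonamide at the far end of these molecules would shift the number, and whether such a shift would be the same on both cores.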